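Notes on the anilino substituent in the lactam series

A few compounds are considered here, and "the series" means these few. Any claim that something is new, unique, unknown or untested is made for them only; others in the source may bear on it.

Three members of the series have a number in a functional assay on NCI-H1299 cells (Homo sapiens) for antiproliferative activity, read by MTT assay, with a stated time of 72 h; a lower number here means a stronger inhibitor, a higher number a weaker inhibitor. Compound 1 `O=C(C1=C(OC2CCCCC2)C(=O)N(CCCn2ccnc2)C1c1ccc(Br)cc1)c1ccccc1` gives 19900 nM. Compound 2 `O=C(C1=C(Nc2ccc(F)cc2)C(=O)N(CCCn2ccnc2)C1c1ccc(Br)cc1)c1ccccc1` gives 25400 nM. Compound 3 `O=C(C1=C(Nc2ccc(Cl)cc2)C(=O)N(CCCn2ccnc2)C1c1ccc(Br)cc1)c1ccccc1` gives 25000 nM. None of the pairs is separated beyond the scatter: a 1.3-fold higher number from compound 1 to compound 2 (0.11 log units; within the scatter), a 1.3-fold higher number from compound 1 to compound 3 (0.10 log units; within the scatter) and a 1.0-fold lower number from compound 2 to compound 3 (0.01 log units; within the scatter). Compound 3 therefore sits with compounds 1 and 2 in a single band, and nothing among these three numbers tells the cyclohexyloxy group apart from either anilino group, or the fluoro apart from the chloro.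

Compound 4 `O=C(C1=C(Nc2ccc(OC(F)(F)F)cc2)C(=O)N(CCCn2ccnc2)C1c1ccc(Br)cc1)c1ccccc1` is the next member to be measured. It differs from compound 3 in one place: trifluoromethoxy in place of chloro on an aromatic carbon. Within the data shown here, the only measured step at this aromatic carbon is a 1.0-fold lower number from compound 2 to compound 3 (0.01 log units; within the scatter), within the scatter. The wider steps that exchange the whole group on the double-bonded ring carbon, a 1.3-fold higher number from compound 1 to compound 2 (0.11 log units; within the scatter) and a 1.3-fold higher number from compound 1 to compound 3 (0.10 log units; within the scatter), are likewise within the scatter. Among the measured compounds shown here, no measured step in this assay has moved the number beyond the scatter, so for compound 4 no step beyond the scatter is expected, in either direction; the expected step is no change at the digits printed from compound 3 to compound 4 (within the scatter). Compound 4 is accordingly estimated at 25000 nM, with a range from 12000 nM to 50000 nM.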

Compound 4, half-maximal inhibitory concentration: 11500 nM
The estimate for compound 4 lay 2.2-fold (0.34 log units) above the measured number; measured number below the stated range.
By their numbers in this assay, from the lowest: compounds 4, 1, 3 and 2 (each within the scatter of the next, the first and the last beyond it).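

In this assay this aromatic carbon, para to a large group, now responds to the exchange of its substituent, which the fluoro and chloro pair had not shown: trifluoromethoxy in place of chloro gives a 2.2-fold lower number from compound 3 to compound 4 (0.34 log units; beyond the scatter) and trifluoromethoxy in place of fluoro gives a 2.2-fold lower number from compound 2 to compound 4 (0.34 log units; beyond the scatter), the only steps in the four compounds that lie beyond the scatter. The change is not large enough to separate the new anilino group from the cyclohexyloxy group, with a 1.7-fold lower number from compound 1 to compound 4 (0.24 log units; within the scatter), so the effect can be read only among the three anilino compounds, and compound 1 remains within the scatter of all of them. No measurement is at hand that bears on why the trifluoromethoxy group differs from the two halogens.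

A methoxy or a trifluoromethyl group on the same carbon would show whether the lower number goes with the oxygen link, with the fluorines or with neither. On these data alone, it also remains open whether the step holds when the bromo group on the shared core is exchanged for an amine or a nitrile.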